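Swapping the 1,3-benzoxazol-2-yl group of compound 1

A few compounds are considered here, and "the series" means these few. Any claim that something is new, unique, unknown or untested is made for them only; others in the source may bear on it.

- compound 1 `CCn1cc(-c2nc3ccccc3o2)c(=O)c2cc(F)c(N3CCNCC3)nc21` gives 11700 nM
- compound 2 `CCn1cc(-c2nc3ccc([N+](=O)[O-])cc3o2)c(=O)c2cc(F)c(N3CCNC(C)C3)c(F)c21` gives 600 nM
- compound 3 `CCn1cc(-c2nc3ccc([N+](=O)[O-])cc3o2)c(=O)c2cc(F)c(N3CCNCC3)nc21` gives 1800 nM

All three numbers come from a functional assay on KB cells (Homo sapiens) for cytotoxicity, read by MTT assay, with a stated time of 48 h (a lower number here means a stronger inhibitor, a higher number a weaker inhibitor), and compound 1 has the highest of them. Compound 4 `CCn1cc(-c2nc3ccc(N)cc3[nH]2)c(=O)c2cc(F)c(N3CCNCC3)nc21` has not yet been measured. It differs from compound 1 in one place: a group of 10 heavy atoms (7 carbon, 3 nitrogen; one five-membered aromatic ring with 2 hetero atoms, one six-membered aromatic ring of carbon only) in place of a group of 9 heavy atoms (7 carbon, 1 nitrogen, 1 oxygen; one five-membered aromatic ring with 2 hetero atoms, one six-membered aromatic ring of carbon only), on an aromatic carbon. In words, the 1,3-benzoxazol-2-yl group leaves and a group with no common name enters, on an aromatic carbon of the core.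

Within the data shown here, the only measured step in one place is a 6.5-fold lower number from compound 1 to compound 3 (0.81 log units; beyond the scatter), with nitro in place of hydrogen on an aromatic carbon. Among the measured compounds shown here, it is a loose guide: compound 4 carries no nitro group, and no measured step replaces the whole group. Resting on a 6.5-fold lower number from compound 1 to compound 3 (0.81 log units; beyond the scatter), a modest step to a lower number, no larger than that one, is expected in this assay, with wide uncertainty. The estimated step is a 2.3-fold lower number from compound 1 to compound 4 (0.37 log units; beyond the scatter), and it may prove smaller. For compound 4 the estimated value is 5000 nM, with an expected range of 1000 nM to 25000 nM.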

Compound 4, half-maximal inhibitory concentration: 30100 nM
Beside the measured number, compound 4's estimate is 6.0-fold (0.78 log units) below it; measured number outside the range, above it.
By their numbers in this assay, from the lowest: compound 2; then compound 3; then compound 1; then compound 4.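

In this assay, the group on this aromatic carbon of the core can push the number up as well as down: there is a 2.6-fold higher number from compound 1 to compound 4 (0.41 log units; beyond the scatter), whereas the earlier step was a 6.5-fold lower number from compound 1 to compound 3 (0.81 log units; beyond the scatter). The new change is also a double one, since the ring oxygen gives way to a ring nitrogen carrying hydrogen and an amine is added, taking the group from 0 to 2 hydrogen-bond donors. Nothing available explains why the number rose.

The compounds shown leave open which of these two edits accounts for the rise, as neither appears alone here. They also leave open how a hydroxyl or a carboxylic acid would behave where compound 3 carries its nitro group.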